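This account rests on a few compounds, and the source may have more. Where it says the series, first, only, none or still open, it means among the compounds named here.

Measured compounds:
compound 1 `O=Cc1cc(O)c(O)c(Br)c1Br`, 30900 nM
compound 2 `CCCOCc1cc(O)c(O)c(Br)c1Br`, 12400 nM
compound 3 `OCc1cc(O)c(O)c(Br)c1Br`, 18300 nM

In a functional assay on DLD-1 cells (Homo sapiens) for cytotoxicity, read by MTT assay, with a stated time of 96 h (on this read-out higher numbers stand for weaker inhibition and lower numbers for stronger inhibition), compound 3 stands second highest of the three, within the scatter of both neighbours: a 1.5-fold higher number from compound 2 to compound 3 (0.17 log units; within the scatter) and a 1.7-fold lower number from compound 1 to compound 3 (0.23 log units; within the scatter). Compound 4 `COCc1cc(O)c(O)c(Br)c1Br` differs from compound 3 by methyl in place of hydrogen on an oxygen on a saturated carbon. Going by the values given here, the one measured step at that same oxygen, a 1.5-fold higher number from compound 2 to compound 3 (0.17 log units; within the scatter), stayed within the scatter, and compound 2 with its propyl sits close to compound 3. A methyl on that oxygen is therefore expected to move the number little, if at all, with any drift leaning slightly toward a lower number; the expected step is a 1.2-fold lower number from compound 3 to compound 4 (0.09 log units; within the scatter). Compound 4 is estimated at 15000 nM, with a range from 7000 nM to 32000 nM.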

Compound 4, half-maximal inhibitory concentration: 14600 nM
Beside the measured number, compound 4's estimate is 1.0-fold (0.01 log units) above it; the measured number falls inside the stated range.
By their numbers in this assay, from the lowest: compounds 2, 4, 3 and 1 (each within the scatter of the next, the first and the last beyond it).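

In this assay, methyl on the oxygen gives a 1.3-fold lower number from compound 3 to compound 4 (0.10 log units; within the scatter), and the shorter ether set against the propyl one gives a 1.2-fold higher number from compound 2 to compound 4 (0.07 log units; within the scatter), so hydrogen, methyl and propyl on this oxygen all lie within the scatter of one another. Methoxymethyl in place of formyl gives a 2.1-fold lower number from compound 1 to compound 4 (0.33 log units; beyond the scatter), beyond the scatter but modest, so both ethers, and not only the propyl one, now stand apart from the aldehyde compound 1. Nothing measured here accounts for these numbers.

As far as these compounds go, whether a much longer chain, a benzyl group or an amine at this carbon would move the number further remains open.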